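The source may hold more compounds than are shown below. What is called first, only, known or untested is meant among the compounds shown, and "the series" means these compounds.

Values in a functional assay on Hep 3B2 cells (Homo sapiens) for cytotoxicity, read by MTT assay, with a stated time of 6 days; a higher number here means a weaker inhibitor, a lower number a stronger inhibitor:
- Compound 1 `Cc1cc2c(cc1Cl)N(Cc1cn(Cc3ccccc3)nn1)C(=O)CO2`: > 100000 nM
- Compound 2 `Cc1ccc2c(c1)N(Cc1cn(Cc3ccccc3)nn1)C(=O)CO2`: > 100000 nM

Compound 2 has no numerical value, because its > 100000 nM is a limit of the assay. Compound 1 also gives only a limit, > 100000 nM. The whole measured set therefore sits together: the limit of > 100000 nM in this assay, at which 2 of the 2 values shown sit.

Compound 3 `O=C1COc2ccc(Cl)cc2N1Cc1cn(Cc2ccccc2)nn1` is the next case. It differs from compound 2 by chloro in place of methyl on an aromatic carbon. Going by the values given here, no step between measured compounds is available to size this change in this assay, so no shift beyond the scatter is expected, and the direction stays open. The expected change is a number no higher from compound 2 to compound 3 (the limit leaves the size open). This expectation rests on the limit of compound 2, > 100000 nM. Compound 3 is estimated at 100000 nM, with an expected range of 40000 nM to 250000 nM.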

Compound 3, half-maximal inhibitory concentration: 55500 nM
Compound 3: the middle estimate sits 1.8-fold (0.26 log units) above what was measured, and the stated range covers the measured number.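

In this assay compound 3 gives 55500 nM, the first number rather than a limit in this set, so the shared core with chloro on this aromatic carbon now reads within the range of the assay. Chloro in place of methyl on an aromatic carbon gives an at least 1.8-fold lower number from compound 2 to compound 3 (0.25 log units; that floor lies within the scatter), and the loss of methyl gives an at least 1.8-fold lower number from compound 1 to compound 3 (0.25 log units; that floor lies within the scatter). Going by these compounds, both steps are floors whose true size stays unknown, because compound 1 and compound 2 each carry only a limit: the limit of > 100000 nM in this assay, at which 2 of the 3 values shown sit.

On these data alone, how the core would read with an amine or a methoxy group on this aromatic carbon stays open. Whether the number of compound 3 belongs to chloro itself or simply to the loss of methyl also remains unsettled.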